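Swapping benzamido for a carbamate side chain

The source may hold more compounds than are shown below. What is called first, only, known or untested is meant among the compounds shown, and "the series" means these compounds.

compound 1 `COc1cc(NC(=O)Nc2cccc(C)c2)ccc1-c1cnco1` gives 1000 nM
compound 2 `Cn1cc(C#N)c2ccc(Nc3ncc(-c4ccccc4CN)o3)cc21` gives 1100 nM
compound 3 `Cn1cc(C#N)c2ccc(Nc3ncc(-c4cccc(NC(=O)c5ccccc5)c4)o3)cc21` gives 3500 nM

These three numbers come from a functional assay on CCRF-CEM cells (Homo sapiens) for inhibition; a lower number here means a stronger inhibitor, a higher number a weaker inhibitor. Among them, compound 3 stands highest at 3500 nM, which makes it the weakest inhibitor of the three, and its gaps to the other two lie beyond the scatter of repeat measurements.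

Compound 4 `Cn1cc(C#N)c2ccc(Nc3ncc(-c4cccc(CNC(=O)OC5CCOC5)c4)o3)cc21` keeps the core of compound 3 but carries ((((oxolan-3-yl)oxy)carbonyl)amino)methyl in place of benzamido on an aromatic carbon. For the measured compounds named here, no measured pair shows what a swap of this kind does, so any forecast rests on thin evidence. Going by the values given here, the only other compound with this core, compound 2, gives 1100 nM, so the core itself can reach lower numbers than compound 3 does. A modest move to a lower number is therefore expected in this assay, and the estimated step is a 2.3-fold lower number from compound 3 to compound 4 (0.37 log units; beyond the scatter), not far beyond the scatter. For compound 4 the expected value is 1500 nM, with an estimated range from 400 nM to 5000 nM.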

Compound 4, half-maximal inhibitory concentration: > 10000 nM
Compound 4: only a limit was reported; the forecaster's own chance of this, stated with the estimate: 5%; at least 6.6-fold (0.82 log units) between middle value and limit.
By their numbers in this assay, from the lowest: compounds 1 and 2 (each within the scatter of the next); then compound 3. At a limit, above all of these: compound 4.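

In this assay, replacing benzamido with ((((oxolan-3-yl)oxy)carbonyl)amino)methyl on this aromatic carbon, meta to a large group, gives an at least 2.8-fold higher number from compound 3 to compound 4 (0.45 log units; beyond the scatter). This position is therefore sensitive to the group it carries, and this change moves the number upward, beyond the scatter, rather than toward the lower values the opening compounds might have suggested. The full size of the step cannot be read because compound 4 reaches only a limit of the assay, not an exact number: the limit of > 10000 nM in this assay, at which 1 of the 4 values shown sits.

The change replaces a six-membered aromatic ring with a five-membered non-aromatic ring and alters the linking atoms at the same time, so these compounds cannot show which part drives the loss. A phenyl carbamate or a simple morpholine at this position would help separate those parts.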